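Ethyl on the anilino nitrogen of compound 2

The source may report more compounds than this note shows. Statements on the series, on what has been measured and on what is new or still open speak of the compounds shown alone.

Measured so far:
Compound 1 `Cc1cccc(S(=O)(=O)NCc2ccc(C(=O)Nc3cccnc3)cc2)c1` — < 1000 nM
Compound 2 `Cc1cccc(Nc2nc(-c3ccnc(-c4cn(CCOCCOCCOCCOCCOCCOCCN)nn4)c3)cs2)c1` — > 40000 nM

Both readings in a functional assay on RCC4 cells (Homo sapiens) for cytotoxicity, read by XTT assay, with a stated time of 4 days (a lower number here means a stronger inhibitor, a higher number a weaker inhibitor), are limits of the assay, not numbers. Compound 1 stands at the limit of < 1000 nM in this assay, at which 1 of the 2 values shown sits. Compound 2 stands at the limit of > 40000 nM in this assay, at which 1 of the 2 values shown sits, so its true potency is known only as a range open at the weak end; it is the weaker of the two readings in this assay. Compound 3 `CCN(c1cccc(C)c1)c1nc(-c2ccnc(-c3cn(CCOCCOCCOCCOCCOCCOCCN)nn3)c2)cs1` differs from compound 2 by ethyl in place of hydrogen on a nitrogen on an aromatic ring. Among the measured compounds shown here, no step between measured compounds is available to gauge a change of this kind, and the two measured compounds share no common structure that would let the change be read across. The expected step in this assay is a number no higher from compound 2 to compound 3 (the limit leaves the size open), none beyond the scatter, and the reading for compound 3 is expected to stay a limit. Compound 3 is estimated at 40000 nM, within 15000 nM to 100000 nM.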

Compound 3, half-maximal inhibitory concentration: > 40000 nM
Compound 3 ended at the assay's limit; the forecaster's own chance of this, stated with the estimate: 80%; the middle value lies on the limit itself.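

No step can be read between compound 2 and compound 3: both readings are limits of the assay, not numbers. The compounds shown leave open the true potency of each, and what ethyl in place of hydrogen on a nitrogen on an aromatic ring does to it.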